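The compounds below may be only part of what the source reports. "The series", "measured", "known", "first", "only" and "open" are said of these compounds alone.

Measured in an assay on cells for inhibition of cytochrome P450 11B2, mitochondrial (Homo sapiens), read by HTRF; a higher number here means a weaker inhibitor, a lower number a stronger inhibitor:
compound 1 `CC(=O)N[C@@H]1CCCc2c1cncc2N1C(=O)c2ccc(Cl)cc2[C@H]1C`, 130 nM
compound 2 `CCC(=O)N[C@@H]1CCCc2c1cncc2N1Cc2cc(Cl)ccc2C1=O`, 28 nM
compound 3 `CC(=O)N[C@@H]1CCCc2c1cncc2N1C(=O)c2ccc(Cl)cc2[C@@H]1C`, 4 nM

Compound 3 gives the lowest number of the three in this assay; compound 2 stands nearest to it and compound 1 furthest. Compound 4 `CC(=O)N[C@@H]1CCCc2c1cncc2N1Cc2cc(Cl)ccc2C1=O` differs from compound 3 by hydrogen in place of methyl on a saturated ring carbon. For the measured compounds named here, the one measured step touching this carbon is a 33-fold lower number from compound 1 to compound 3 (1.51 log units; beyond the scatter), which rests on the fact that compounds 1 and 3 differ only in the configuration as drawn and shows that what sits there weighs heavily. Taking the methyl away removes that stereocentre, so part of the gain of compound 3 over compound 1 is expected to be lost. Compound 2, which also carries hydrogen at that carbon, gives 28 nM. For compound 4 the expected step is a 6.3-fold higher number from compound 3 to compound 4 (0.80 log units; beyond the scatter), toward a higher number. Compound 4 is estimated at 25 nM, within 8 nM to 80 nM.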

Compound 4, half-maximal inhibitory concentration: 44 nM
Compound 4: middle estimate off by 1.8-fold (0.25 log units), on the low side, and the stated range covers the measured number.
By their numbers in this assay, from the lowest: compound 3; then compounds 2 and 4 (each within the scatter of the next); then compound 1.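

Replacing methyl with hydrogen on the saturated ring carbon gives an 11-fold higher number from compound 3 to compound 4 (1.04 log units; beyond the scatter) but a 3.0-fold lower number from compound 1 to compound 4 (0.47 log units; beyond the scatter), so in this assay the methyl lowers or raises the number relative to hydrogen according to its configuration: the fact that compounds 1 and 3 differ only in the configuration as drawn

Replacing methyl with hydrogen at the other site, a saturated chain carbon bound to a carbonyl carbon, gives a 1.6-fold higher number from compound 2 to compound 4 (0.20 log units; within the scatter), so that change does not separate the two compounds.

Open, from the compounds shown here alone, is whether ethyl or hydroxymethyl on the ring carbon, in the configuration of compound 3, would keep the low number of that compound.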